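Methyl for isopropoxy on the sulfonamide aryl ring

The source may report more compounds than this note shows. Statements on the series, on what has been measured and on what is new or still open speak of the compounds shown alone.

Compound 1 `Cc1c(C(=O)O)c(-c2cccc(N3CCN(c4ccc(NS(=O)(=O)c5ccc(N[C@H](CCN6CCC(O)CC6)CSc6ccccc6)c(S(=O)(=O)C(F)(F)F)c5)cc4)CC3)c2)c(-c2ccc(Cl)cc2)n1C` — 10.2 nM
Compound 2 `Cc1c(C(=O)NCCCN2CCN(C)CC2)c(-c2cccc(N3CCN(c4ccc(NS(=O)(=O)c5cccc(OC(C)C)c5)cc4)CC3)c2)c(-c2ccc(Cl)cc2)n1C` — 2020 nM
Compound 3 `Cc1c(C(=O)O)c(-c2cccc(N3CCN(c4ccc(NS(=O)(=O)c5ccc(N[C@H](CCN6CCC(C)(O)CC6)CSc6ccccc6)c(S(=O)(=O)C(F)(F)F)c5)cc4)CC3)c2)c(-c2ccc(Cl)cc2)n1C` — 18.6 nM

In an assay for inhibition of Apoptosis regulator Bcl-2 (Homo sapiens), read by fluorescence polarization, with a stated time of 2 h (on this read-out higher numbers stand for weaker inhibition and lower numbers for stronger inhibition), compound 2 stands at the highest of the three numbers; its gaps to compound 3 and to compound 1 both lie beyond the usual scatter of repeated measurements, so compound 2 is the weakest inhibitor among the measured set. Compound 4 `Cc1cccc(S(=O)(=O)Nc2ccc(N3CCN(c4cccc(-c5c(C(=O)NCCCN6CCN(C)CC6)c(C)n(C)c5-c5ccc(Cl)cc5)c4)CC3)cc2)c1` has not yet been measured. It differs from compound 2 in one place only: methyl in place of isopropoxy on an aromatic carbon. Among the measured compounds shown here, no pair of measured compounds shows this change, so the size of the step cannot be read from the data; compounds 1 and 3 carry a far larger group on the same ring and cannot serve as a comparison. Given how small the change is, the step from compound 2 to compound 4 is expected to be a 1.5-fold higher number from compound 2 to compound 4 (0.17 log units; within the scatter) in this assay, a slight move toward weaker inhibition that may well sit within the scatter. Compound 4 is therefore expected to give 3000 nM, with a range from 1000 nM to 9000 nM.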

Compound 4, half-maximal inhibitory concentration: 689 nM
Compound 4: middle estimate off by 4.4-fold (0.64 log units), on the high side; the measured number lies below the stated range.
By their numbers in this assay, from the lowest: compounds 1 and 3 (each within the scatter of the next); then compound 4; then compound 2.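

In this assay the change from 3-isopropoxyphenyl to 3-methylphenyl gives a 2.9-fold lower number from compound 2 to compound 4 (0.47 log units; beyond the scatter) and so shows that this place on the aromatic ring, meta to a large group, responds measurably to the group it carries. The isopropoxy, with its oxygen and four heavy atoms, is therefore not required for the inhibition seen in compound 2, and a single methyl carbon does better here. No measurement is available that explains this step.

Going by these compounds, whether the shift follows the loss of the oxygen or the smaller size of the group stays open, and a methoxy or an ethyl at this place would help to separate the two. On these data alone, it is also open whether the step would hold if a carboxylic acid replaced the amide chain carried by both compounds.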